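Triazole substituent swap at compound 3: ester to thiophene

The source may report more compounds than this note shows. Statements on the series, on what has been measured and on what is new or still open speak of the compounds shown alone.

Measured so far:
compound 1 `CCS[C@@H]1[C@H](SCC)[C@@H](Cn2cc(-c3ccccc3)nn2)O[C@H]1n1ccc(=O)[nH]c1=O` 6590 nM
compound 2 `CCS[C@@H]1[C@H](SCC)[C@@H](Cn2cc(-c3ccc(F)cc3)nn2)O[C@H]1n1ccc(=O)[nH]c1=O` 37400 nM
compound 3 `CCOC(=O)c1cn(C[C@H]2O[C@@H](n3ccc(=O)[nH]c3=O)[C@H](SCC)[C@@H]2SCC)nn1` >= 100000 nM

All three share one core and differ only in the group on the triazole. In a functional assay on HeLa cells (Homo sapiens) for cytotoxicity, read by MTT assay, with a stated time of 72 h (a higher number here means that more compound is needed for the effect, a lower number that less compound is needed), compound 1 gives 6590 nM. Compound 2 gives 37400 nM in this assay. For compound 3 the value >= 100000 nM is a limit of this assay, not a number; it is the limit of >= 100000 nM in this assay, at which 1 of the 3 values shown sits, and compound 3 therefore stands at the weak end of what has been measured.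

Compound 4 `CCS[C@@H]1[C@H](SCC)[C@@H](Cn2cc(-c3cccs3)nn2)O[C@H]1n1ccc(=O)[nH]c1=O` is not yet measured. It differs from compound 3 by thiophen-2-yl in place of ethoxycarbonyl on an aromatic carbon.

Among the measured compounds shown here, two measured steps bear on this change, both running toward the ester: an at least 15-fold higher number from compound 1 to compound 3 (1.18 log units; beyond the scatter) and an at least 2.6-fold higher number from compound 2 to compound 3 (0.42 log units; beyond the scatter). Reversing the direction, replacing the ester by an aromatic five-membered ring, is expected to lower the number in this assay, by a large step, and compound 4 is estimated at an at least 8.3-fold lower number from compound 3 to compound 4 (0.92 log units; beyond the scatter). Compound 4 is expected to give about 12000 nM, within 4000 nM to 50000 nM.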

Compound 4, half-maximal effective concentration: >= 100000 nM
Compound 4 ended at the assay's limit; the forecaster's own chance of this, stated with the estimate: 10%; at least 8.3-fold (0.92 log units) between middle value and limit.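

In this assay compound 4 gives a limit of the assay, not a number, and compound 3 stands at the same limit: the limit of >= 100000 nM in this assay, at which 2 of the 4 values shown sit. The step between these two compounds cannot be read. Thiophen-2-yl is set apart from the other aromatic groups at this position, with an at least 15-fold higher number from compound 1 to compound 4 (1.18 log units; beyond the scatter) and an at least 2.6-fold higher number from compound 2 to compound 4 (0.42 log units; beyond the scatter), so an aromatic ring here does not by itself keep the number in the measurable range, as compound 1 and compound 2 alone had suggested.

The compounds shown leave open whether this holds for five-membered aromatic rings in general, which furan-2-yl at the same position would test. From the compounds shown here alone, how a carboxylic acid or an aminomethyl group would read in this assay also remains open.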